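This account rests on a few compounds, and the source may have more. Where it says the series, first, only, none or still open, it means among the compounds named here.

Of the compounds shown here, three sharing one core have been measured in a functional assay on MIA PaCa-2 cells (Homo sapiens) for antiproliferative activity, read by sulforhodamine B assay, with a stated time of 48 h; a higher number here means a weaker inhibitor, a lower number a stronger inhibitor. Compound 1 `COc1cc(C(=O)/C=C\Nc2ccc(-c3nc4cc(OC)c(OC)c(OC)c4s3)cc2)c(Br)c(OC)c1OC` gives 23200 nM, and compound 2 `COc1ccc(C(=O)/C=C\Nc2ccc(-c3nc4cc(OC)c(OC)c(OC)c4s3)cc2)cc1O` gives 32800 nM. Compound 3 `COc1cc(C(=O)/C=C\Nc2ccc(-c3nc4cc(OC)c(OC)c(OC)c4s3)cc2)cc([N+](=O)[O-])c1OC` gives 15800 nM, a number within the scatter of compound 1 and lower than that of compound 2 by a margin just beyond the scatter. No two of these compounds differ in one place only, so no single-change step has been measured.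

Compound 4 `COc1cc(C(=O)/C=C\Nc2ccc(-c3nc4cc(OC)c(OC)c(OC)c4s3)cc2)cc(OC)c1OC` departs from compound 3 by one change, methoxy in place of nitro on an aromatic carbon. With compound 3 at 15800 nM and compound 2 at 32800 nM, the measured values span little more than the scatter, so no step beyond the scatter is expected in this assay, and no firm direction can be given. The estimated change is small, a 1.1-fold lower number from compound 3 to compound 4 (0.05 log units; within the scatter). For compound 4 the expected value is 14000 nM, with an estimated range from 4500 nM to 35000 nM.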

Compound 4, half-maximal inhibitory concentration: 29100 nM
Estimate against measurement, compound 4: 2.1-fold (0.32 log units) below; the measured number falls inside the stated range.
By their numbers in this assay, from the lowest: compounds 3, 1, 4 and 2 (each within the scatter of the next, the first and the last beyond it).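

In this assay, methoxy in place of nitro on an aromatic carbon ortho to a methoxy group gives a 1.8-fold higher number from compound 3 to compound 4 (0.27 log units; within the scatter) and so does not separate the two groups at this position. Among the compounds shown here, compound 4 also provides the first single-change readings at two other places, hydrogen in place of bromo on an aromatic carbon giving a 1.3-fold higher number from compound 1 to compound 4 (0.10 log units; within the scatter) and 3,4,5-trimethoxyphenyl in place of 3-hydroxy-4-methoxyphenyl on a carbonyl carbon giving a 1.1-fold lower number from compound 2 to compound 4 (0.05 log units; within the scatter) with both steps as small as the first. No measurement bears on why these steps are so small.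

As far as these compounds go, it remains open whether any group on this aromatic carbon can move the number beyond the scatter, for instance an amine, a carboxylic acid or a longer alkoxy chain. The same question stands for the linking chain and the shared core, where the compounds shown carry no variation.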